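This account rests on a few compounds, and the source may have more. Where it says the series, first, only, none or still open, it means among the compounds named here.

In an in vivo ADME assay on the whole organism (Rattus norvegicus) for pharmacokinetics (on this read-out lower numbers stand for lower oral bioavailability and higher numbers for higher oral bioavailability), compound 3 `COCC1=C(C(=O)NCCCN2CCC(c3ccc(F)cc3C#N)CC2)[C@@H](c2ccc(F)c(F)c2)NC(=O)N1` gives < 6%, which is a limit and not a number. Compound 1 `COCC1=C(C(=O)NCCCN2CCC(c3ccccc3C#N)CC2)[C@@H](c2ccc(F)c(F)c2)NC(=O)N1` gives < 6%, also a limit. Compound 2 `N#Cc1cc(F)ccc1C1CCN(CCCNC(=O)C2=CNC(=O)N[C@@H]2c2ccc(F)c(F)c2)CC1` gives 0%. Compound 4 `COCC1=C(C(=O)NCCCN2CCC(c3ccccn3)CC2)[C@@H](c2ccc(F)c(F)c2)NC(=O)N1` differs from compound 3 by one swap on a saturated ring carbon: pyridin-2-yl in place of 2-cyano-4-fluorophenyl on a saturated ring carbon. Two measured steps sit nearby, a step that the two limits leave unreadable from compound 1 to compound 3 and a step that the limit leaves unreadable from compound 2 to compound 3, but neither makes this swap and neither has a readable size. The nearest guide is therefore (the limit of < 6% in this assay, at which 2 of the 3 values shown sit). A clear rise in this assay is not expected because compound 3 gives < 6%. The expected step is small, a number no lower from compound 3 to compound 4 (the limit leaves the size open). The estimate for compound 4 is 6%, with an expected range from 0% to 20%.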

Compound 4, oral bioavailability: 0%
Compound 4: the middle estimate sits 6 percentage points above what was measured; the measured number falls inside the stated range.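

Neither step to compound 4, from compound 3 or from compound 1, can be read, since both starting values are limits and not numbers. In this assay the compounds shown leave open how large a difference, if any, these swaps make.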